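Acid ceramidase series: oxopiperazine in place of piperazine

The source may hold more compounds than are shown below. What is called first, only, known or untested is meant among the compounds shown, and "the series" means these compounds.

Measured compounds:
compound 1 `CC(C)N1CCN(c2ccc3c(c2)oc(=O)n3C(=O)NCCCCc2ccccc2)CC1` — 211 nM
compound 2 `O=C(NCCCCc1ccccc1)n1c2c(oc1=O)CNCC2` — 340 nM

Both compounds were tested in an assay on HEK293 cells for inhibition of acid ceramidase (Homo sapiens), read by fluorescence, with stated times of 10 min and 3 h; a lower number here means a stronger inhibitor, a higher number a weaker inhibitor. Compound 1 gives 211 nM and compound 2 gives 340 nM. Within the data shown here, the two numbers lie within the usual scatter of each other, so neither compound stands apart, and no step between measured compounds that differ in one place is available to guide the next change.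

Compound 3 `CN1CCN(c2ccc3c(c2)oc(=O)n3C(=O)NCCCCc2ccccc2)C(=O)C1` has not yet been measured. It differs from compound 1 in one place: 4-methyl-2-oxopiperazin-1-yl in place of 4-isopropylpiperazin-1-yl on an aromatic carbon. The group that leaves and the group that enters are both a six-membered non-aromatic ring with two hetero atoms carrying the same count of hydrogen-bond acceptors and no donors; the entering group is one heavy atom smaller and brings a double bond outside aromatic rings.

Among the measured compounds shown here, with no measured step to rest on, the expectation comes from the structural change alone. A modest weakening is expected, a 2.4-fold higher number from compound 1 to compound 3 (0.37 log units; beyond the scatter), a step that may or may not reach beyond the scatter. Compound 3 is accordingly estimated at 500 nM, with a range from 150 nM to 1500 nM.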

Compound 3, half-maximal inhibitory concentration: 52 nM
For compound 3 the middle estimate is 9.6-fold (0.98 log units) above the measured one; measured number below the stated range.
By their numbers in this assay, from the lowest: compound 3; then compounds 1 and 2 (each within the scatter of the next).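

In this assay, among these compounds, the change to 4-methyl-2-oxopiperazin-1-yl from 4-isopropylpiperazin-1-yl on this aromatic carbon gives a 4.1-fold lower number from compound 1 to compound 3 (0.61 log units; beyond the scatter) and is the first single-place comparison; compound 1 and compound 2 differ in more than one place, so they could not show that this substituent alone moves the number beyond the scatter. The entering ring is one heavy atom smaller and brings a double bond outside aromatic rings, with the hydrogen-bond donor and acceptor counts unchanged, so the difference in the number arises without any change in those counts. No measurement available here bears on why the number falls.

The step alters the ring carbonyl and the substituent on the ring nitrogen together, and 4-methylpiperazin-1-yl or 4-isopropyl-2-oxopiperazin-1-yl would be needed to separate those two parts. As far as these compounds go, it also remains open whether the lower number extends to other rings at this place, such as morpholin-4-yl, or holds with a longer chain on the amide of the shared core.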